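The compounds below may be only part of what the source reports. "The series", "measured", "known", "first", "only" and "open" are said of these compounds alone.

Within the data shown here, compound 2 `CCCCCCCc1cc2cn(COCCO)c(=O)nc2o1` is the one member of the series with a number on the read-out: in a functional assay on HEL cells (Homo sapiens), read by microscopy (on this read-out higher numbers stand for lower toxicity in this test and lower numbers for higher toxicity in this test), compound 2 gives 400000 nM. Compound 1 `CCCCCCCCCc1cc2cn(COCCO)c(O)nc-2n1` returns only a limit of the assay in this assay, > 80000 nM, the value meant by the limit of > 80000 nM in this assay, at which 1 of the 2 values shown sits. Compound 3 `CCCCCc1cc2cn(COCCO)c(=O)nc2o1` has not yet been measured; it differs from compound 2 by hydrogen in place of ethyl on a saturated chain carbon, five bonds along the chain from an aromatic carbon. Among the measured compounds shown here, no step between two measured compounds exists in this set, so nothing here shows how a change in chain length moves the minimum cytotoxic concentration. The shortening of the chain is expected to produce a step of a 1.3-fold higher number from compound 2 to compound 3 (0.10 log units; within the scatter), that is, a move within the usual scatter or a modest move toward lower toxicity, with the limit of the assay a real possibility. For compound 3 a minimum cytotoxic concentration of 500000 nM is estimated, expected to fall between 200000 nM and 1200000 nM.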

Compound 3, minimum cytotoxic concentration: > 400000 nM
Compound 3 ended at the assay's limit; the forecaster's own chance of this, stated with the estimate: 35%; the middle value is on the limit's open side.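

In this assay, among these compounds, the series now has its only readable comparison, a number no lower from compound 2 to compound 3 (the limit leaves the size open), for hydrogen in place of ethyl on a saturated chain carbon, five bonds along the chain from an aromatic carbon. Shortening the chain at this place therefore brings no sign of higher toxicity in this test, which no earlier pair could show, although the size of the move remains unknown. The result for compound 3 is a limit of the assay and not a number: the limit of > 400000 nM in this assay, at which 1 of the 3 values shown sits.

As far as these compounds go, how far compound 3 lies from compound 2 stays open, and with a single step no trend along the chain can be claimed. Also open, from the compounds shown here alone, is whether a longer chain, or an amine or a carboxylic acid in place of the ethyl at this place, would lower the minimum cytotoxic concentration.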